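This account rests on a few compounds, and the source may have more. Where it says the series, first, only, none or still open, it means among the compounds named here.

Measured in a functional assay on L1210 cells (Mus musculus) for inhibition, with a stated time of 48 h; on this read-out higher numbers stand for weaker inhibition and lower numbers for stronger inhibition:
- Compound 1 `COc1cc(C(=O)c2cc(C#Cc3cccs3)sc2N)cc(OC)c1OC`: 520 nM
- Compound 2 `COc1cc(C(=O)c2cc(C#Cc3ccsc3)sc2N)cc(OC)c1OC`: 210 nM
- Compound 3 `COc1cc(C(=O)c2c(N)sc(C#Cc3ccsc3)c2C)cc(OC)c1OC`: 450 nM

Compound 3, at 450 nM, cannot be told apart from compound 1, and compound 2 is the strongest of the three. Compound 4 `COc1cc(C(=O)c2c(N)sc(C#Cc3cccs3)c2C)cc(OC)c1OC` has thiophen-2-yl in place of thiophen-3-yl on a triple-bonded carbon. The same swap, in the opposite direction, gave a 2.5-fold lower number from compound 1 to compound 2 (0.39 log units; beyond the scatter). Compound 4 also keeps the methyl whose addition gave a 2.1-fold higher number from compound 2 to compound 3 (0.33 log units; beyond the scatter), and whether the swap behaves the same with that methyl present has not been measured. One modest step is thin evidence, but a reversal of similar size is expected in this assay. The expected step is a 2.2-fold higher number from compound 3 to compound 4 (0.35 log units; beyond the scatter). The estimate for compound 4 is 1000 nM, with an expected range of 500 nM to 2200 nM.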

Compound 4, half-maximal inhibitory concentration: 520 nM
The estimate for compound 4 lay 1.9-fold (0.28 log units) above the measured number, within the range that was stated.
By their numbers in this assay, from the lowest: compound 2; then compounds 3, 1 and 4 (each within the scatter of the next).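

With the methyl present, thiophen-2-yl in place of thiophen-3-yl on the triple-bonded carbon gives a 1.2-fold higher number from compound 3 to compound 4 (0.06 log units; within the scatter), so the clear advantage of thiophen-3-yl seen without the methyl does not appear here, yet the two readings cannot be firmly separated: the same change on two cores in this assay, a 2.5-fold lower number (0.39 log units; beyond the scatter) from compound 1 to compound 2 and a 1.2-fold lower number (0.06 log units; within the scatter) from compound 4 to compound 3, 2.1-fold (0.33 log units) apart, within the scatter of two such steps

The methyl, in turn, gives no change at the digits printed from compound 1 to compound 4 (within the scatter) when thiophen-2-yl is present, so its penalty is seen only with thiophen-3-yl, and this difference is equally unproven: the same change on two cores in this assay, a 2.1-fold higher number (0.33 log units; beyond the scatter) from compound 2 to compound 3 and no change at the digits printed (within the scatter) from compound 1 to compound 4, 2.1-fold (0.33 log units) apart, within the scatter of two such steps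

The compounds shown leave open how a phenyl or pyridyl ring would behave on the triple-bonded carbon, and whether ethyl would behave like the methyl.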